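Adding a Second Chloro to a Benzylpurine Core

The compounds below may be only part of what the source reports. "The series", "measured", "known", "first", "only" and "open" are said of these compounds alone.

Measured compounds:
Compound 1 `ClCc1ccc(Cn2cnc3c(Cl)ncnc32)cc1` gives 2040 nM in a functional assay on HCC 2998 cells (Homo sapiens) for cytotoxicity, read by sulforhodamine B assay, with a stated time of 48 h; a lower number here means a stronger inhibitor of growth, a higher number a weaker inhibitor of growth.
Compound 2 `Nc1nc(Cl)c2ncn(Cc3ccccc3CCl)c2n1` gives 6610 nM.
Compound 3 `ClCc1cccc(Cn2cnc3nc(Cl)nc(Cl)c32)c1` gives 3310 nM.

Compound 1 has the lowest of the three numbers in this assay. Compound 3 lies within the usual scatter of it, so the two cannot be ordered; compound 2 sits beyond the scatter with the higher number. Compound 4 `ClCc1ccc(Cn2cnc3c(Cl)nc(Cl)nc32)cc1` has not been measured. It differs from compound 1 in one place: chloro in place of hydrogen on an aromatic carbon. Going by the values given here, no measured pair isolates this chloro-for-hydrogen change, so the direction of its effect is not known from these data. The step from compound 1 to compound 4 is expected to be small, a 1.2-fold higher number from compound 1 to compound 4 (0.09 log units; within the scatter), no larger than the scatter in either direction. Compound 4 is therefore estimated at 2500 nM, with a range from 1000 nM to 6500 nM.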

Compound 4, concentration for total growth inhibition: 24000 nM
Compound 4: the middle estimate sits 9.6-fold (0.98 log units) below what was measured, and the stated range ends below it.
By their numbers in this assay, from the lowest: compounds 1, 3 and 2 (each within the scatter of the next, the first and the last beyond it); then compound 4.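

In this assay, going by these compounds alone, chloro in place of hydrogen on the aromatic carbon between two ring nitrogen atoms brings a 12-fold higher number from compound 1 to compound 4 (1.07 log units; beyond the scatter) and gives the first single-change reading at this position. This carbon on the core of compound 1 is therefore far from indifferent to substitution: one added chlorine atom leaves a much weaker inhibitor of growth. Nothing at hand gives a reason for this loss. The compounds shown leave open whether the loss is specific to chloro or would also follow from fluoro, methyl or methoxy at this carbon.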